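Swapping fluoro for cyano on the pendant ring

The source may report more compounds than this note shows. Statements on the series, on what has been measured and on what is new or still open speak of the compounds shown alone.

Three compounds share an amide-linked core and were measured in an assay for inhibition of apolipoprotein B-100 (Homo sapiens), tested at 100 nM; on this read-out higher numbers stand for weaker inhibition and lower numbers for stronger inhibition. Compound 1 `COC(=O)N[C@@H]1Cc2ccc(NC(=O)c3ccccc3-c3ccc(C(F)(F)F)cc3)cc2C1` gives 5.2 nM in this assay. Compound 2 `COC(=O)N[C@H]1Cc2ccc(NC(=O)c3cc(C)ccc3-c3ccc(C(F)(F)F)cc3)cc2C1` gives 2.2 nM. Compound 3 `Cc1cccc(C(=O)Nc2ccc3c(c2)CC(NS(=O)(=O)c2ccccc2)C3)c1-c1ccc(F)cc1` gives 1.2 nM, which places it at the low end of the three numbers; the value of compound 2 sits within the usual scatter of it, while the value of compound 1 lies beyond that scatter.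

Compound 4 `Cc1cccc(C(=O)Nc2ccc3c(c2)CC(NS(=O)(=O)c2ccccc2)C3)c1-c1ccc(C#N)cc1` differs from compound 3 in one place: cyano in place of fluoro on an aromatic carbon. Among the compounds with values here, no pair of measured compounds shows this change, so there is no measured step to lean on. The expectation is therefore a step no larger than the scatter in either direction, expressed as a 1.3-fold higher number from compound 3 to compound 4 (0.10 log units; within the scatter). On that basis compound 4 is estimated at 1.5 nM in this assay, with a range from 0.5 nM to 5 nM.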

Compound 4, half-maximal inhibitory concentration: 5.5 nM
For compound 4 the middle estimate is 3.7-fold (0.56 log units) below the measured one; measured number above the stated range.
By their numbers in this assay, from the lowest: compounds 3 and 2 (each within the scatter of the next); then compounds 1 and 4 (each within the scatter of the next).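

In this assay, exchanging the 4-fluorophenyl for a 4-cyanophenyl gives a 4.6-fold higher number from compound 3 to compound 4 (0.66 log units; beyond the scatter), so this position, para to a large group, responds to the change by a modest step that lies beyond the scatter. Within the data shown here, the earlier compounds offered no pair differing in one place, which makes this the first measured step in the set, and it rests on this single pair alone. Nothing among the data shown accounts for the step.

From the compounds shown here alone, it remains open whether the same exchange would give a step of similar size and direction on the core of compound 1 or compound 2, which carry a trifluoromethyl group on the pendant ring. Going by these compounds, how a chloro, methoxy or amine group at this position would compare with fluoro and cyano also remains open.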